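The compounds below may be only part of what the source reports. "The series", "measured", "known", "first", "only" and "open" are said of these compounds alone.

Measured compounds:
Compound 1 `CCCCNC(=O)CC1CCc2cc(OC)c(OC)cc21`, which in a functional assay on the whole organism (strain Wistar) for inhibition, with Rattus norvegicus as the target, read by paw edema, with stated times of 60 min and 6 h, at a dose of 100 mg/kg by the oral route (a higher number here means more inhibition at the dose given (going by the name of the read-out), a lower number less inhibition), gives 24.1%.
Compound 2 `COc1cc2c(cc1OC)C(CC(=O)N1CCCC1)CC2`, which in this assay gives 22.2%.

Among the two numbers in this assay compound 2 stands as the lower one, but its nearest neighbour, compound 1, lies only a number 1.9 percentage points lower from compound 1 to compound 2 (within the scatter), so the two compounds are not separable on these data. Compound 3 `COc1cc2c(cc1OC)C(CC(=O)N1CCNCC1)CC2` has not yet been measured in this assay. It differs from compound 2 as follows: piperazin-1-yl in place of pyrrolidin-1-yl on a carbonyl carbon. Going by the values given here, the only measured step, from compound 1 to compound 2, also exchanged the group on the carbonyl carbon, and it moved the read-out by a number 1.9 percentage points lower from compound 1 to compound 2 (within the scatter), within the scatter. Among the compounds with values here, no step with piperazin-1-yl itself is known, so the expectation rests on that single exchange alone. Compound 3 is therefore expected to show no step beyond the scatter in this assay, with a step of about a number 0.2 percentage points lower from compound 2 to compound 3 (within the scatter) estimated. Compound 3 is estimated at 22%, within a range from 8% to 38%.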

Compound 3, a percentage reported as inhibition, in the whole organism at one dose (the size of the read-out at that dose, not a potency): 33.3%
Estimate against measurement, compound 3: 11.3 percentage points below; the range from low to high includes it.
By their numbers in this assay, from the lowest: compounds 2, 1 and 3 (each within the scatter of the next, the first and the last beyond it).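

In this assay the group on the carbonyl carbon now proves able to move the read-out beyond the scatter, which the exchange of butylamino for pyrrolidin-1-yl had not shown: piperazin-1-yl in place of pyrrolidin-1-yl gives a number 11.1 percentage points higher from compound 2 to compound 3 (beyond the scatter) and is a modest step. The same group in place of butylamino gives a number 9.2 percentage points higher from compound 1 to compound 3 (within the scatter) and so leaves compound 3 not separable from compound 1, which means the gain holds only against compound 2. Piperazin-1-yl brings a six-membered ring with a second nitrogen and the hydrogen-bond donor and acceptor counted for it, but nothing at hand links any of these features to the step.

The compounds shown leave open whether the second ring nitrogen with its hydrogen matters, a question that morpholin-4-yl or 4-methylpiperazin-1-yl on the same carbonyl carbon would address. They also leave open whether the step would persist with a longer chain between the shared core and the carbonyl, and how it would look at other doses, since a reading at one dose is not a potency.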